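Removing a ring methyl on a second core

The source may report more compounds than this note shows. Statements on the series, on what has been measured and on what is new or still open speak of the compounds shown alone.

Four compounds share the design of an enone linked to an anilino group that carries a substituted benzothiazole. Compound 2 `COc1cc(C(=O)/C=C\Nc2ccc(-c3nc4cc(OC)c(OC)c(OC)c4s3)cc2C)c(Br)c(OC)c1OC` and compound 1 `COc1cc(C(=O)/C=C\Nc2ccc(-c3nc4cc(OC)c(OC)c(OC)c4s3)cc2)c(Br)c(OC)c1OC` share one core; in a functional assay on MIA PaCa-2 cells (Homo sapiens) for antiproliferative activity, read by sulforhodamine B assay, with a stated time of 48 h (a lower number here means a stronger inhibitor, a higher number a weaker inhibitor), compound 2 gives 24300 nM and compound 1 gives 23200 nM. The change between them, (hydrogen in place of methyl on an aromatic carbon), produced a 1.0-fold lower number from compound 2 to compound 1 (0.02 log units; within the scatter). Compound 3 `COc1ccc2nc(-c3ccc(N/C=C\C(=O)c4cc(OC)c(OC)c(OC)c4Br)c(C)c3)sc2c1` has a different core; how the two cores differ is not broken down here. In this assay compound 3 gives 23400 nM. Compound 4 `COc1ccc2nc(-c3ccc(N/C=C\C(=O)c4cc(OC)c(OC)c(OC)c4Br)cc3)sc2c1` relates to compound 3 by hydrogen in place of methyl on an aromatic carbon. This is the same kind of change as before, although the place differs: in compound 3 the carbon sits meta to a 6-methoxy-1,3-benzothiazol-2-yl group, where before it was meta to a large group. Because a 1.0-fold lower number from compound 2 to compound 1 (0.02 log units; within the scatter) lay within the scatter, the step expected is a 1.0-fold lower number from compound 3 to compound 4 (0.01 log units; within the scatter). For compound 4 the estimate in this assay is 23000 nM, expected between 12000 nM and 46000 nM.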

Compound 4, half-maximal inhibitory concentration: 14700 nM
Estimate against measurement, compound 4: 1.6-fold (0.19 log units) above, within the range that was stated.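

On the second core, the same swap of methyl for hydrogen in this assay gives a 1.6-fold lower number from compound 3 to compound 4 (0.20 log units; within the scatter) and so does not separate the two compounds. Set beside the earlier step, it does not differ from it: the same change on two cores in this assay, a 1.0-fold lower number (0.02 log units; within the scatter) from compound 2 to compound 1 and a 1.6-fold lower number (0.20 log units; within the scatter) from compound 3 to compound 4, 1.5-fold (0.18 log units) apart, within the scatter of two such steps. This shows that, in these two pairs, removing the ring methyl leaves the number within the scatter on both cores, but two pairs cannot show that this would hold on other cores in the series.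

The compounds shown leave open whether a different group on that aromatic carbon, such as an amine, a carboxylic acid or a longer chain, would move the number beyond the scatter. They also leave open whether the same swap would behave alike in other cell lines.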